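Removing the ring methyl in the benzyl-type series

The source may hold more compounds than are shown below. What is called first, only, known or untested is meant among the compounds shown, and "the series" means these compounds.

The series is built on a shared core carrying two substituted imine arms, one bearing a branched alkyl group and the other a substituted benzyl-type group. Compound 2 `Cc1cc(Cl)cc(Cl)c1C/N=c1\c(O)c(O)\c1=N/C(C)(C)C` gives 220 nM in a functional assay for inhibition, with Rattus norvegicus as the target; a lower number here means a stronger inhibitor, a higher number a weaker inhibitor. Compound 1 `CC(C)(C)/N=c1\c(O)c(O)\c1=N/Cc1ccc(Cl)cc1Cl` is the matched partner of compound 2; in this assay compound 1 gives 1300 nM. The step between them is a 5.9-fold higher number from compound 2 to compound 1 (0.77 log units; beyond the scatter); the change is hydrogen in place of methyl on an aromatic carbon.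

Compound 3 `CCC(C)(C)/N=c1\c(O)c(O)\c1=N/Cc1c(C)cc(C)cc1C` carries a different core from compound 2, and how the two cores differ is not broken down here. In this assay compound 3 gives 310 nM, which sits within the scatter of compound 2 and well apart from compound 1.

Compound 4 `CCC(C)(C)/N=c1\c(O)c(O)\c1=N/Cc1ccc(C)cc1C` has not yet been measured. It differs from compound 3 by hydrogen in place of methyl on an aromatic carbon. Going by the values given here, this is the same kind of change as the one from compound 2 to compound 1, not the same: in compound 3 the leaving methyl is meta to two methyl groups, whereas in compound 2 it is meta to two chloro groups.

Among the compounds with values here, on the single comparable step, the expectation is that compound 4 will be a weaker inhibitor than compound 3, with a step estimated at a 4.8-fold higher number from compound 3 to compound 4 (0.68 log units; beyond the scatter), resting on the step seen from compound 2 to compound 1 because of a 5.9-fold higher number from compound 2 to compound 1 (0.77 log units; beyond the scatter). The value for compound 4 in this assay is therefore estimated at 1500 nM, expected to fall between 500 nM and 4500 nM.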

Compound 4, half-maximal inhibitory concentration: 530 nM
Compound 4: the middle estimate sits 2.8-fold (0.45 log units) above what was measured, and the stated range covers the measured number.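

Across the two cores, the replacement of methyl by hydrogen on an aromatic carbon does not give one transferable step in this assay. On the second core, the replacement gives a 1.7-fold higher number from compound 3 to compound 4 (0.23 log units; within the scatter), so the large shift seen on the first core does not recur there, and the size of the step has to be read core by core: the same change on two cores in this assay, a 5.9-fold higher number (0.77 log units; beyond the scatter) from compound 2 to compound 1 and a 1.7-fold higher number (0.23 log units; within the scatter) from compound 3 to compound 4, 3.5-fold (0.54 log units) apart, beyond the scatter of two such steps

This shows only that the size of the step differs between these two matched pairs; the direction of the second step cannot be read, and two pairs set no rule for any further core in the series. The pairs also differ from each other both in the branched alkyl arm and in the other ring substituents, chloro groups in one pair and methyl groups in the other, so the data do not tell which of these differences goes with the difference in step size.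

Among the compounds shown, the chloro groups occur with only one of the two alkyl arms, which leaves those two features unseparated. Also open, going by these compounds, is how a group other than methyl on the same ring carbon, such as a methoxy group or an amine, would read on either core.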